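The compounds below may be only part of what the source reports. "The series", "measured", "known", "first", "only" and "open" are said of these compounds alone.

Compound 3, `CC[C@@H](Nc1c(C#N)c(-c2ccc(-c3ccncc3C)cc2)nc2cnccc12)C(N)=O`, is the starting point of this step. For the measured compounds named here, in a physicochemical assay for lipophilicity, read by HPLC, at pH 7.5 (a higher number here means a more lipophilic compound, a lower number a more polar compound), compound 3 gives 2, the lowest of the three numbers measured so far, though neither gap sets it apart: a number 0.10 log units lower from compound 1 to compound 3 (within the scatter), and a number 0.20 log units lower from compound 2 to compound 3 (within the scatter). The two comparison compounds are compound 1, `CC[C@@H](Nc1c(C#N)c(-c2ccc(-c3ccccc3CO)cc2)nc2cnccc12)C(N)=O`, which in this assay gives 2.1, and compound 2, `CC[C@@H](Nc1c(C#N)c(-c2ccc(Br)cc2)nc2cnccc12)C(N)=O`, which in this assay gives 2.2; between them, a number 0.10 log units higher from compound 1 to compound 2 (within the scatter). All three share one core and differ only at one aromatic carbon.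

Compound 4, `CC[C@@H](Nc1c(C#N)c(-c2ccc(-c3cccc(Cl)c3OC)cc2)nc2cnccc12)C(N)=O`, carries the change (3-chloro-2-methoxyphenyl in place of 3-methylpyridin-4-yl on an aromatic carbon). Going by the values given here, no measured step swaps in this exact group. Among the compounds with values here, the steps that bear on it are the two that change the same position, a number 0.10 log units lower from compound 1 to compound 3 (within the scatter) and a number 0.20 log units lower from compound 2 to compound 3 (within the scatter), both small. Because a number 0.10 log units lower from compound 1 to compound 3 (within the scatter) was within the scatter, exchanging the pyridine-containing group for a carbon-only ring is expected to move the number little, with a slight rise allowed for the larger entering group. The estimate for compound 4 is therefore 2.6, between 2.2 and 3, an expected step of a number 0.60 log units higher from compound 3 to compound 4 (beyond the scatter).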

Compound 4, distribution coefficient: 3.1
For compound 4 the middle estimate is 0.50 log units below the measured one; measured number outside the range, above it.
By their numbers in this assay, from the lowest: compounds 3, 1 and 2 (each within the scatter of the next); then compound 4.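

At this position on the shared core, the group can matter in this assay after all: the three groups seen earlier gave numbers within the scatter of one another, while 3-chloro-2-methoxyphenyl stands apart from all of them, with a number 1.10 log units higher from compound 3 to compound 4 (beyond the scatter) and a number 0.90 log units higher from compound 2 to compound 4 (beyond the scatter) and a number 1.00 log units higher from compound 1 to compound 4 (beyond the scatter) for the same exchange at this carbon. The step away from 3-methylpyridin-4-yl replaces a ring with one hetero atom by a ring of carbon only and also brings in chlorine and oxygen, and these changes arrive together in compound 4, so they cannot be told apart. Nothing available explains the rise.

Going by these compounds, how much of the rise belongs to the chlorine and how much to the methoxy stays open, and a 3-chlorophenyl or a 2-methoxyphenyl group at this carbon would separate them. Also open, on these data alone, is how the number would respond to an amine or a carboxylic acid on the entering ring.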